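Alkyl Growth on the Sulfonyl Group and Rat Plasma Clearance

A few compounds are considered here, and "the series" means these few. Any claim that something is new, unique, unknown or untested is made for them only; others in the source may bear on it.

The measured compounds and their values:
compound 1, `CCS(=O)(=O)n1cc2c(n1)CN([C@H]1CO[C@H](c3cc(F)ccc3F)[C@@H](N)C1)C2`: 1.6 mL/min/kg
compound 2, `CC(C)S(=O)(=O)n1cc2c(n1)CN([C@H]1CO[C@H](c3cc(F)ccc3F)[C@@H](N)C1)C2`: 7 mL/min/kg
compound 3, `CS(=O)(=O)Nc1n[nH]c2c1CN([C@H]1CO[C@H](c3cc(F)ccc3F)[C@@H](N)C1)C2`: 16 mL/min/kg

All three were run in an ADME assay on the whole organism (plasma) for pharmacokinetics, with Rattus norvegicus as the target; on this read-out higher numbers stand for fast clearance and lower numbers for slow clearance. Compound 2 differs from compound 1 by methyl in place of hydrogen on a saturated chain carbon bound to a saturated chain carbon and a sulfonyl sulfur, and this gave a 4.4-fold higher number from compound 1 to compound 2 (0.64 log units; beyond the scatter). Compound 3 carries a different core; the difference between the two cores is not broken down here. Its number in this assay is the highest of the three, standing above both compound 2 and compound 1.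

Compound 4, `CCS(=O)(=O)Nc1n[nH]c2c1CN([C@H]1CO[C@H](c3cc(F)ccc3F)[C@@H](N)C1)C2`, has not yet been measured. It differs from compound 3 by methyl in place of hydrogen on a saturated chain carbon bound to a sulfonyl sulfur. The place is not word for word the same as in the earlier pair: in compound 1 the carbon that gains the methyl is bound to a saturated chain carbon and a sulfonyl sulfur, whereas in compound 3 it is bound to a sulfonyl sulfur only, so this is the same kind of change, not the same change. Because compound 3 already gives 16 mL/min/kg and the earlier step gave a 4.4-fold higher number from compound 1 to compound 2 (0.64 log units; beyond the scatter), compound 4 is expected to show a 2.0-fold higher number from compound 3 to compound 4 (0.30 log units; within the scatter) in this assay. Compound 4 is therefore estimated at 32 mL/min/kg, between 14 mL/min/kg and 65 mL/min/kg.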

Compound 4, clearance: 12 mL/min/kg
Beside the measured number, compound 4's estimate is 2.7-fold (0.43 log units) above it, outside the stated range (below it).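

In this assay, methyl in place of hydrogen on a saturated chain carbon bound to a sulfonyl sulfur gave a 1.3-fold lower number from compound 3 to compound 4 (0.12 log units; within the scatter), so on this core the change from methanesulfonamido to (ethylsulfonyl)amino left clearance indistinguishable within the usual scatter. This shows that the step seen on the core of compound 1 did not carry over unchanged to the core of compound 3: the same change on two cores in this assay, a 4.4-fold higher number (0.64 log units; beyond the scatter) from compound 1 to compound 2 and a 1.3-fold lower number (0.12 log units; within the scatter) from compound 3 to compound 4, 5.8-fold (0.77 log units) apart, beyond the scatter of two such steps. It does not show why the two results part, whether the core itself or the different surroundings of the carbon that gains the methyl lie behind the gap, and two pairs give no rule for any other core in the series.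

The compounds shown leave open how a longer chain, such as propyl, or a branched isopropyl group on the sulfonyl would behave on the core of compound 3. They also leave open whether a cyclopropyl group there would follow the core of compound 1 or the core of compound 3.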